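The source may report more compounds than this note shows. Statements on the series, on what has been measured and on what is new or still open speak of the compounds shown alone.

Compound 1 `O=C(N/N=C/c1cc(I)c(O)c(I)c1)c1ccc(F)cc1` carries a fluoro group on its outer ring and is tested in a functional assay on HepG2 cells (Homo sapiens) for cytotoxicity, with a stated time of 24 h (on this read-out higher numbers stand for weaker inhibition and lower numbers for stronger inhibition), where compound 1 gives 117000 nM. Compound 2 `O=C(N/N=C/c1cc(I)c(O)c(I)c1)c1ccc(Cl)cc1` differs from it by chloro in place of fluoro on an aromatic carbon. In this assay compound 2 returns only a limit of the assay, > 100000 nM, and not a number. The step that the limit leaves unreadable from compound 1 to compound 2 therefore cannot be read because of the limit of > 100000 nM in this assay, at which 1 of the 3 values shown sits. Compound 3 `O=C(NNC(=O)c1cc(I)cc(I)c1O)c1ccc(F)cc1` is built on another core; the difference between the two cores is not broken down here. In this assay compound 3 gives 87000 nM, and against compound 1 this sits within the usual scatter, so no order between the two can be claimed. Compound 4 `O=C(NNC(=O)c1cc(I)cc(I)c1O)c1ccc(Cl)cc1` has not yet been measured. It differs from compound 3 by chloro in place of fluoro on an aromatic carbon, the same change that separates compound 1 from compound 2. Going by the values given here, the one measured instance of this change is hidden behind the limit; its size is not known from the data. The expectation for compound 4 therefore rests on compound 3 and its value 87000 nM alone. The step of a 1.1-fold higher number from compound 3 to compound 4 (0.06 log units; within the scatter) is expected to be small. Compound 4 is estimated at 100000 nM, between 50000 nM and 200000 nM, with a fair chance that this assay again reports only a limit.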

Compound 4, half-maximal inhibitory concentration: 48700 nM
For compound 4 the middle estimate is 2.1-fold (0.31 log units) above the measured one; the whole stated range lies above it.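

On the core of compound 3, chloro in place of fluoro gives a 1.8-fold lower number from compound 3 to compound 4 (0.25 log units; within the scatter) in this assay, so no order between these two compounds can be claimed, and this pair gives no sign that the swap of 4-fluorophenyl to 4-chlorophenyl matters on this core. Going by these compounds alone, the same change on the core of compound 1 cannot be read, because compound 2 returns only a limit of the assay and not a number: the limit of > 100000 nM in this assay, at which 1 of the 4 values shown sits. The series therefore holds a single readable instance of this change, and it shows neither that the change behaves alike on the two cores nor that it behaves differently, since there is no second step to set against the first.

The outer ring of the compounds shown carries only fluoro or chloro, so it remains open how this assay would read with an amine or a carboxylic acid in that place. On these data alone, it also remains open whether a longer chain, such as a butyl group, would give a step beyond the scatter on either core, and whether the core of compound 1 would then follow the core of compound 3.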